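A few compounds are considered here, and "the series" means these few. Any claim that something is new, unique, unknown or untested is made for them only; others in the source may bear on it.

Compound 1 `CC(=O)OCCC(=O)O[C@H](CC=C(C)C)C1=CC(=O)c2c(O)ccc(O)c2C1=O` gives 15700 nM in a functional assay on DU-145 cells (Homo sapiens) for cytotoxicity, read by MTT assay (a higher number here means a weaker inhibitor, a lower number a stronger inhibitor), the second highest of the three numbers measured: compound 2 `CC(C)=CC[C@@H](OC(=O)C1CCCO1)C1=CC(=O)c2c(O)ccc(O)c2C1=O` gives 10500 nM, and compound 3 `CCCC(C)(O)CC(=O)O[C@H](CC=C(C)C)C1=CC(=O)c2c(O)ccc(O)c2C1=O` gives 75000 nM. The step of a 1.5-fold lower number from compound 1 to compound 2 (0.17 log units; within the scatter) lies within the scatter, whereas a 4.8-fold higher number from compound 1 to compound 3 (0.68 log units; beyond the scatter) lies beyond it. Compound 4 `CC(C)=CC[C@@H](OC(=O)CC(O)c1ccccc1)C1=CC(=O)c2c(O)ccc(O)c2C1=O` differs from compound 1 by hydroxy(phenyl)methyl in place of acetoxymethyl on a saturated chain carbon bound to a carbonyl carbon. The step from compound 1 to compound 3 bears most on this change, since it also placed a group carrying a hydroxy on the saturated chain carbon bound to the carbonyl carbon and raised the number modestly. A modest rise is therefore expected for compound 4, with a 2.2-fold higher number from compound 1 to compound 4 (0.35 log units; beyond the scatter). The estimate for compound 4 is 35000 nM, within a range from 12000 nM to 100000 nM.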

Compound 4, half-maximal inhibitory concentration: 17000 nM
For compound 4 the middle estimate is 2.1-fold (0.31 log units) above the measured one; low and high end bracket the measured number.
By their numbers in this assay, from the lowest: compounds 2, 1 and 4 (each within the scatter of the next); then compound 3.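

At this place, on a saturated chain carbon bound to a carbonyl carbon, hydroxy(phenyl)methyl can stand in for acetoxymethyl in this assay without a readable change: a 1.1-fold higher number from compound 1 to compound 4 (0.03 log units; within the scatter) and a 1.6-fold higher number from compound 2 to compound 4 (0.21 log units; within the scatter) both stay within the scatter. A hydroxy on this chain carbon thus does not by itself go with the rise seen for compound 3, as a 4.4-fold lower number from compound 3 to compound 4 (0.64 log units; beyond the scatter) separates two groups that both carry one. Nothing available explains this gap between the two groups. Still open, on these data alone, is what a benzyl group without the hydroxy, or an amine in place of that hydroxy, would give in this assay.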